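The source may hold more compounds than are shown below. What is called first, only, known or untested is meant among the compounds shown, and "the series" means these compounds.

Compound 3 `Cc1ccc(Nc2ncc3c(n2)N(C)C(=O)N(c2cc(NC(=O)c4cccc(C(F)(F)F)c4)ccc2C)C3)cc1N` gives 440 nM in an ADME assay on BaF3 cells (Mus musculus) for antiproliferative activity, read by CellTiter-Glo and CCK-8 assay, with a stated time of 72 h (a lower number here means a stronger inhibitor of growth, a higher number a weaker inhibitor of growth), the lowest of the two numbers shown; compound 1 `Cc1ccc(Nc2ncc3c(n2)N(C)C(=O)N(c2cc(NC(=O)c4cccc(C(F)(F)F)c4)ccc2C)C3)cc1C` gives 3760 nM, and the step of an 8.5-fold lower number from compound 1 to compound 3 (0.93 log units; beyond the scatter) lies beyond the scatter. Compound 2 `Cc1ccc(NC(=O)c2cccc(C(F)(F)F)c2)cc1N1Cc2cnc(Nc3ccc(C)c(C(F)(F)F)c3)nc2N(C)C1=O` reaches only the limit > 10000 nM in this assay. Compound 4 `Cc1cc(C)cc(C(=O)Nc2ccc(C)c(N3Cc4cnc(Nc5ccc(C)c(N)c5)nc4N(C)C3=O)c2)c1` differs from compound 3 by 3,5-dimethylphenyl in place of 3-(trifluoromethyl)phenyl on a carbonyl carbon. The measured steps of an at least 2.6-fold higher number from compound 1 to compound 2 (0.42 log units; beyond the scatter) and an at least 22-fold lower number from compound 2 to compound 3 (1.35 log units; beyond the scatter), like the first, vary only the group on an aromatic carbon of the shared core; none touches the group on the carbonyl carbon, so no direct precedent for this change exists among the numbers shown. The expectation is therefore a step of a 1.4-fold higher number from compound 3 to compound 4 (0.13 log units; within the scatter) in this assay, not beyond the scatter, with no firm direction. Compound 4 is estimated at 600 nM, within 150 nM to 2500 nM.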

Compound 4, concentration for 50% growth inhibition: > 10000 nM
Compound 4: no number, only a limit (the forecaster's own chance of this, stated with the estimate: 5%); at least 16-fold (1.22 log units) between middle value and limit.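

Among these compounds, the group on the carbonyl carbon, not varied in the earlier steps, proves far from interchangeable in this assay: the change gives an at least 22-fold higher number from compound 3 to compound 4 (1.35 log units; beyond the scatter). The amino group of compound 3, kept in compound 4, does not by itself hold the number down. The step gives only a lower bound, since compound 4 reaches a limit of the assay and not a number: the limit of > 10000 nM in this assay, at which 2 of the 4 values shown sit.

Going by these compounds, it remains open whether the loss of trifluoromethyl or the gain of a second methyl drives the step. A 3-methylphenyl or a 3,5-bis(trifluoromethyl)phenyl on the carbonyl carbon would separate the two.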